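This account rests on a few compounds, and the source may have more. Where it says the series, first, only, none or still open, it means among the compounds named here.

Measured compounds:
- compound 1, `CCOC(=O)c1c(-c2ccc(Cl)cc2)cc(-c2ccccc2)nc1N1CCN(C)CC1`: 55.6%
- compound 2, `CCOC(=O)c1c(-c2ccc(Cl)cc2)cc(-c2ccccc2)nc1Nc1ccccc1`: 123%

In a functional assay on the whole organism (strain Wister albino) for inhibition, with Rattus norvegicus as the target, read by paw edema, with stated times of 1 h and 4 h, at a dose of 50 mg/kg by the intraperitoneal route (a higher number here means more inhibition at the dose given (going by the name of the read-out), a lower number less inhibition), compound 1 gives 55.6%, the lowest of the two numbers shown. In this assay compound 2 gives 123%. Between them stands one change, a number 67.4 percentage points higher from compound 1 to compound 2 (beyond the scatter). Compound 3, `CCOC(=O)c1c(-c2ccc(Cl)cc2)cc(-c2ccccc2)nc1Nc1ccc(Cl)cc1`, differs from compound 1 by (4-chlorophenyl)amino in place of 4-methylpiperazin-1-yl on an aromatic carbon. Among the measured compounds shown here, the only step that bears on this is the one from compound 1 to compound 2, which swapped the same group for an anilino group and was large; a similar large rise is therefore expected, a number 54.4 percentage points higher from compound 1 to compound 3 (beyond the scatter). Compound 3 is estimated to give 110%, with a range from 75% to 145%.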

Compound 3, a percentage reported as inhibition, in the whole organism at one dose (the size of the read-out at that dose, not a potency): 95.9%
Compound 3: the middle estimate sits 14.1 percentage points above what was measured; low and high end bracket the measured number.
By their numbers in this assay, from the lowest: compound 1; then compound 3; then compound 2.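

Placing (4-chlorophenyl)amino on this aromatic carbon instead of 4-methylpiperazin-1-yl also raises the number in this assay (a number 40.3 percentage points higher from compound 1 to compound 3 (beyond the scatter)), so the gain is not limited to the plain anilino group. Adding chloro to the anilino ring, however, gives back part of that gain (a number 27.1 percentage points lower from compound 2 to compound 3 (beyond the scatter)). Nothing available explains either step.

From the compounds shown here alone, whether the drop is specific to chloro stays open, as a methoxy or methyl group at that spot on the anilino ring could behave differently. Going by these compounds, an open-chain amine such as dimethylamino also remains untested here as a replacement for the ring groups.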